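A few compounds are considered here, and "the series" means these few. Any claim that something is new, unique, unknown or untested is made for them only; others in the source may bear on it.

Working notes on the series, read in a functional assay on HeLa cells (Homo sapiens) for cytotoxicity, read by MTT assay, with a stated time of 48 h; on this read-out lower numbers stand for stronger inhibition and higher numbers for weaker inhibition. Compound 2 `O=C(O)CN1C(=O)/C(=C/c2nc3ccccc3n2Cc2ccccc2F)SC1=S` gives 640 nM, the lowest of the two true numbers in the set, while compound 1 `O=C(O)CN1C(=O)/C(=C/c2nc3ccccc3n2Cc2ccc(Br)cc2)SC1=S` gives 12900 nM. Compound 3 `O=C(O)CN1C(=O)/C(=C/c2nc3ccccc3n2Cc2cccc(F)c2)SC1=S` reads > 50000 nM, which is a limit of the assay and not a number. All measured steps swap the phenyl group on the saturated chain carbon bound to an aromatic nitrogen. They are a 20-fold lower number from compound 1 to compound 2 (1.30 log units; beyond the scatter), an at least 3.8-fold higher number from compound 1 to compound 3 (0.58 log units; beyond the scatter) and an at least 78-fold higher number from compound 2 to compound 3 (1.89 log units; beyond the scatter), the last two resting on that limit.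

Compound 4 `O=C(O)CN1C(=O)/C(=C/c2nc3ccc(Cl)cc3n2Cc2ccccc2F)SC1=S` keeps the 2-fluorophenyl of compound 2 and changes elsewhere: chloro in place of hydrogen on an aromatic carbon. For the measured compounds named here, no measured step touches that place, so these steps show only that the read-out can move sharply, and they give no direction. A step near the scatter is expected in this assay, leaning upward since compound 2 at 640 nM holds the lowest number. The estimated step is a 1.6-fold higher number from compound 2 to compound 4 (0.19 log units; within the scatter). For compound 4 the expected value is 1000 nM, with an estimated range of 200 nM to 6000 nM.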

Compound 4, half-maximal inhibitory concentration: 7620 nM
For compound 4 the middle estimate is 7.6-fold (0.88 log units) below the measured one, and the stated range ends below it.
By their numbers in this assay, from the lowest: compound 2; then compounds 4 and 1 (each within the scatter of the next). At a limit, above all of these: compound 3.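

The earlier steps shown here all swapped the phenyl group, and this one shows that the six-membered aromatic ring of carbon only, part of a fused or bridged system of two rings, also moves the read-out in this assay: chloro in place of hydrogen on an aromatic carbon gives a 12-fold higher number from compound 2 to compound 4 (1.08 log units; beyond the scatter). With the 2-fluorophenyl kept, the single added chlorine goes with weaker inhibition, so of the two groups shown at this place, hydrogen holds the lower number. Nothing shown gives a cause for this step.

The compounds shown hold only hydrogen and chloro at this place, so how a methoxy group or an amine there would read stays open. Going by these compounds, whether chloro moves the number in the same direction with the 4-bromophenyl of compound 1 is also open.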